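Fluoro step on the 4-methoxyphenyl series

The compounds below may be only part of what the source reports. "The series", "measured", "known", "first", "only" and "open" are said of these compounds alone.

Values in a functional assay on K562 cells (Homo sapiens) for cytotoxicity, read by trypan blue exclusion, with a stated time of 96 h (a lower number here means a stronger inhibitor, a higher number a weaker inhibitor), so far:
- compound 1 `COc1cc(OC)c(/C=C/S(=O)(=O)Nc2ccc(F)c(N)c2)c(OC)c1` gives 5000 nM
- compound 2 `COc1ccc(NS(=O)(=O)/C=C/c2c(OC)cc(OC)cc2OC)cc1` gives 75 nM

Compound 2 holds the lower of the two numbers. Compound 3 `COc1cc(OC)c(/C=C/S(=O)(=O)Nc2ccc(OC)c(F)c2)c(OC)c1` differs from it by fluoro in place of hydrogen on an aromatic carbon and so carries 3-fluoro-4-methoxyphenyl in place of 4-methoxyphenyl. Within the data shown here, the only measured step of a 67-fold lower number from compound 1 to compound 2 (1.82 log units; beyond the scatter) swapped the whole substituted phenyl on the sulfonamide nitrogen, so it sets no size for a single fluoro. No step beyond the scatter is expected, and the estimated step is a 1.3-fold higher number from compound 2 to compound 3 (0.12 log units; within the scatter) in this assay on this basis. For compound 3 the estimate is 100 nM with an expected range from 30 nM to 400 nM in this read-out.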

Compound 3, half-maximal inhibitory concentration: 75 nM
Beside the measured number, compound 3's estimate is 1.3-fold (0.12 log units) above it; low and high end bracket the measured number.
By their numbers in this assay, from the lowest: compounds 2 and 3 (each within the scatter of the next); then compound 1.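

In this assay, fluoro in place of hydrogen on the aromatic carbon ortho to a methoxy group leaves the number unmoved (no change at the digits printed from compound 2 to compound 3 (within the scatter)), so this position accepts the change. The 3-fluoro-4-methoxyphenyl keeps the large gap from the 3-amino-4-fluorophenyl (a 67-fold lower number from compound 1 to compound 3 (1.82 log units; beyond the scatter)). Nothing available explains either step.

From the compounds shown here alone, whether chloro, hydroxy or an amine on this same carbon would read alike stays open. Going by these compounds, compound 1 and compound 3 differ at two ring carbons, so which of these carries the gap also stays open.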